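The compounds below may be only part of what the source reports. "The series", "measured", "known", "first", "only" and "open" are said of these compounds alone.

Measured compounds:
Compound 1 `CC(C)C[C@H](N)C(=O)NS(=O)(=O)c1cccc(-c2ccncc2)c1`: 1200 nM
Compound 2 `CC(C)C[C@H](N)C(=O)NS(=O)(=O)c1ccc2ccccc2c1`: 220 nM

In an assay on isolated protein for inhibition of leucine--tRNA ligase, cytoplasmic (Homo sapiens) (a lower number here means a stronger inhibitor, a higher number a weaker inhibitor), compound 1 gives 1200 nM, the highest of the two numbers; compound 2 gives 220 nM, a lower number beyond the scatter. Among the measured compounds shown here, no step between measured compounds is available to guide the change to compound 3 `Cc1cc(-c2cccc(S(=O)(=O)NC(=O)[C@@H](N)CC(C)C)c2)ncn1`, which differs from compound 1 by 6-methylpyrimidin-4-yl in place of pyridin-4-yl on an aromatic carbon. With nothing comparable measured, only a small step is expected in this assay, likely within the scatter, in either direction. The expected step is a 1.3-fold lower number from compound 1 to compound 3 (0.12 log units; within the scatter). Compound 3 is thus estimated at 900 nM, with a range from 300 nM to 3000 nM.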

Compound 3, half-maximal inhibitory concentration: 2000 nM
For compound 3 the middle estimate is 2.2-fold (0.35 log units) below the measured one, within the range that was stated.
By their numbers in this assay, from the lowest: compound 2; then compounds 1 and 3 (each within the scatter of the next).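

In this assay, 6-methylpyrimidin-4-yl in place of pyridin-4-yl, on an aromatic carbon meta to a large group, gives a 1.7-fold higher number from compound 1 to compound 3 (0.22 log units; within the scatter); at this position, the added ring nitrogen and methyl together do not move the number beyond the scatter. The two additions arrive in one group, so their separate contributions cannot be read. No supporting measurement bears on this result.

Unsubstituted pyrimidin-4-yl would test the methyl on its own. Also open, on these data alone, is whether an amine or a carboxylic acid in place of the ring shifts the number beyond the scatter.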